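Cyclohexyl in place of cyclobutyl on the amine nitrogen

The source may hold more compounds than are shown below. What is called first, only, known or untested is meant among the compounds shown, and "the series" means these compounds.

Measured in an ADME assay on Vero cells (Chlorocebus sabaeus) for cytotoxicity, read by CellTiter-Glo, with a stated time of 72 h; a higher number here means that more compound is tolerated, a lower number that less compound is tolerated:
- compound 1 `CCNc1n[n+]([O-])c2cc(Cl)ccc2[n+]1[O-]`: 2.6 ug/mL
- compound 2 `[O-][n+]1nc(NC2CC2)[n+]([O-])c2ccc(Cl)cc21`: 1.3 ug/mL
- compound 3 `[O-][n+]1nc(NC2CCC2)[n+]([O-])c2ccc(Cl)cc21`: 1.6 ug/mL

Compound 3, at 1.6 ug/mL, cannot be separated from the other two compounds: it lies within the scatter of both. Next is compound 4 `[O-][n+]1nc(NC2CCCCC2)[n+]([O-])c2ccc(Cl)cc21`, with cyclohexyl in place of cyclobutyl on a nitrogen on an aromatic ring. For the measured compounds named here, three measured steps bear on this change: a 2.0-fold lower number from compound 1 to compound 2 (0.30 log units; within the scatter), a 1.6-fold lower number from compound 1 to compound 3 (0.21 log units; within the scatter) and a 1.2-fold higher number from compound 2 to compound 3 (0.09 log units; within the scatter). All stay within the scatter, though none involves cyclohexyl. In this assay, the expected outcome is therefore no clear move in either direction. The estimated step is a 1.1-fold lower number from compound 3 to compound 4 (0.03 log units; within the scatter). For compound 4 the estimate is 1.5 ug/mL, with the measurement expected between 0.7 ug/mL and 3.2 ug/mL.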

Compound 4, half-maximal cytotoxic concentration: 2.6 ug/mL
Compound 4: the middle estimate sits 1.7-fold (0.24 log units) below what was measured, and the stated range covers the measured number.
By their numbers in this assay, from the lowest: compounds 2, 3, 1 and 4 (each within the scatter of the next).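

In this assay the larger ring brings a 1.6-fold higher number from compound 3 to compound 4 (0.21 log units; within the scatter) and a 2.0-fold higher number from compound 2 to compound 4 (0.30 log units; within the scatter) and no change at the digits printed from compound 1 to compound 4 (within the scatter) with all three steps within the scatter. Ethyl, cyclopropyl, cyclobutyl and cyclohexyl on this nitrogen therefore cannot be separated from one another in these four compounds, so the move to a six-membered ring adds no measurable difference. No evidence bearing on this result is available. Still open, as far as these compounds go, is whether a hydroxyl or amine on the cyclohexyl ring, or a phenyl ring in its place, would give a step beyond the scatter.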